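Swapping an amide for an anilino group on a shared core

The source may report more compounds than this note shows. Statements on the series, on what has been measured and on what is new or still open speak of the compounds shown alone.

Measured compounds:
Compound 1 `Cc1cc(C(=O)Nc2ccc3nc(NC(=O)C4CCCCC4)sc3c2)n(C)n1` — 0.12 ug/mL
Compound 2 `Cc1coc(C)c1C(=O)Nc1ccc2nc(NC(=O)C3CCCCC3)sc2c1` — 2.7 ug/mL
Compound 3 `CC(C)CC(=O)Nc1nc2ccc(NC(=O)c3c(Cl)cccc3Cl)cc2s1` — 0.012 ug/mL

Of the three compounds measured in a functional assay on WI-38 VA13 cells (Homo sapiens) for cytotoxicity (a higher number here means that more compound is needed for the effect, a lower number that less compound is needed), compound 3 gives the lowest number, at 0.012 ug/mL. Its nearest neighbour is compound 1, and the most distant is compound 2; both gaps lie beyond the usual scatter, so compound 3 stands apart as the one that needs least material. Going by the values given here, the only single-point step among the measured compounds, a 23-fold higher number from compound 1 to compound 2 (1.35 log units; beyond the scatter), changes the group on the carbonyl carbon at the other end of the shared core, and it is a large one.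

Compound 4 `COc1ccc(Nc2nc3ccc(NC(=O)c4c(Cl)cccc4Cl)cc3s2)cc1` is not yet measured. It differs from compound 3 in one place: 4-methoxyphenyl in place of isobutylcarbonyl on a nitrogen on an aromatic ring. Among the compounds with values here, no measured step touches this nitrogen, so nothing among the three compounds bears directly on the change; the one step known only shows that this core can answer strongly to a change at a single position. Given that, a step of uncertain size is expected, with some lean toward a higher number, and the estimate for compound 4 in this assay is 0.05 ug/mL, between 0.008 ug/mL and 0.4 ug/mL, which is expected to mean a 4.2-fold higher number from compound 3 to compound 4 (0.62 log units; beyond the scatter).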

Compound 4, half-maximal effective concentration: 0.87 ug/mL
Beside the measured number, compound 4's estimate is 17-fold (1.24 log units) below it; measured number above the stated range.
By their numbers in this assay, from the lowest: compound 3; then compound 1; then compound 4; then compound 2.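

In this assay, replacing (isobutylcarbonyl)amino with (4-methoxyphenyl)amino gives a 73-fold higher number from compound 3 to compound 4 (1.86 log units; beyond the scatter). Going by these compounds alone, the nitrogen on an aromatic ring, which no earlier step had touched, is therefore a second place where a single change moves the number strongly, and here the change runs toward more compound being needed. The change removes an open chain with a carbonyl and brings in a six-membered aromatic ring of carbon only, and nothing available explains why the number moves so far.

These two alterations arrive together, so the compounds shown cannot separate the loss of the carbonyl from the gain of the ring. From the compounds shown here alone, a benzoyl group or an unsubstituted phenyl on this nitrogen would bear on that, and the contribution of the methoxy group also remains open.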